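The source may hold more compounds than are shown below. What is called first, only, known or untested is meant among the compounds shown, and "the series" means these compounds.

Measured set:
- compound 1, `C=CCOc1ccccc1C1CC(=O)c2ccccc2O1`; in a functional assay on RAW264.7 cells (Mus musculus) for inhibition, read by immunoassay, with a stated time of 12 h, tested at 30 uM (a lower number here means less inhibition, a higher number more inhibition at the concentration tested (going by the name of the read-out)), compound 1 gives 49.3%
- compound 2, `CC(C)=CCOc1ccccc1C1CC(=O)c2ccccc2O1`; in this assay compound 2 gives 41.8%
- compound 3, `COc1ccccc1C1CC(=O)c2ccccc2O1`; in this assay compound 3 gives 37.3%

Compound 2 holds the second highest of the three numbers. Its nearest neighbour is compound 3, with a number 4.5 percentage points lower from compound 2 to compound 3 (within the scatter), and its furthest is compound 1, with a number 7.5 percentage points lower from compound 1 to compound 2 (within the scatter); both of these gaps lie within the scatter. Among the compounds with values here, the only step beyond the scatter in the set is a number 12 percentage points lower from compound 1 to compound 3 (beyond the scatter), and it is modest.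

Compound 4, `CCCCCOc1ccccc1C1CC(=O)c2ccccc2O1`, is not yet measured. Against compound 2 the change is butyl in place of 2-methylprop-1-en-1-yl on a saturated chain carbon bound to an oxygen on an aromatic ring. Both steps that alter the group on a saturated chain carbon bound to an oxygen on an aromatic ring while starting from or arriving at compound 2 stay within the scatter. Within the data shown here, no measured step trades a chain with a double bond outside aromatic rings for a saturated chain of the same count, so there is no direct guide for that part of the change. The expectation in this assay is therefore a step of no size beyond the scatter, in no settled direction.

Compound 4 is estimated at 40%, with a range from 27% to 53%, which is an expected step of a number 1.8 percentage points lower from compound 2 to compound 4 (within the scatter).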

Compound 4, a percentage reported as inhibition, at one concentration (the size of the read-out at that concentration, not a potency): 41.3%
Beside the measured number, compound 4's estimate is 1.3 percentage points below it; the range from low to high includes it.
By their numbers in this assay, from the lowest: compounds 3, 4, 2 and 1 (each within the scatter of the next, the first and the last beyond it).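

In this assay, replacing 2-methylprop-1-en-1-yl with butyl on a saturated chain carbon bound to an oxygen on an aromatic ring gives a number 0.5 percentage points lower from compound 2 to compound 4 (within the scatter) and so shows, for this pair, that removing the double bond outside aromatic rings at the same carbon count produces no difference that can be read. Within the data shown here, the saturated chain also stays within the scatter of the two other compounds, with a number 4 percentage points higher from compound 3 to compound 4 (within the scatter) and with a number 8 percentage points lower from compound 1 to compound 4 (within the scatter) as the remaining new steps, so the only step beyond the scatter is still a number 12 percentage points lower from compound 1 to compound 3 (beyond the scatter) and it remains modest. Nothing on hand gives a reason for these numbers.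

On these data alone, whether an amine or a carboxylic acid on this chain, or a chain longer than pentyl, would give a step beyond the scatter remains open. Also open, as far as these compounds go, are how these groups would read at any other place on the shared core and how the compounds would rank on potency, as each number here comes from a single concentration.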